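A Halogen Swap on the Benzyl Arm

A few compounds are considered here, and "the series" means these few. Any claim that something is new, unique, unknown or untested is made for them only; others in the source may bear on it.

Compound 1 `O=C1CCc2cc(-n3cnnc3)ccc2N1Cc1ccccc1Cl` gives 300 mg/kg in a functional assay on the whole organism (strain KunMing) with Mus musculus as the target, in the maximal electroshock model, with a stated time of 4 h; a lower number here means that less compound is needed, a higher number that more compound is needed for the effect. Compound 2 `O=C1CCc2cc(-n3cnnc3)ccc2N1Cc1ccc(Cl)cc1Cl` gives 300 mg/kg in this assay, so on these numbers compound 2 stands level with compound 1, as the step of no change at the digits printed from compound 1 to compound 2 (within the scatter) shows. Compound 3 `O=C1CCc2cc(-n3cnnc3)ccc2N1Cc1ccc(F)cc1` has not yet been measured; it differs from compound 2 by 4-fluorophenyl in place of 2,4-dichlorophenyl on a saturated chain carbon bound to an amide-type nitrogen in a ring. Going by the values given here, the one measured step, no change at the digits printed from compound 1 to compound 2 (within the scatter), also altered the group that now leaves and moved nothing, so the expected step of no change at the digits printed from compound 2 to compound 3 (within the scatter) is none beyond the scatter. Compound 3 is therefore estimated at 300 mg/kg in this assay, within 150 mg/kg to 600 mg/kg.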

Compound 3, minimum effective dose: 300 mg/kg
Beside the measured number, compound 3's estimate shows no gap at the digits printed, within the range that was stated.
By their numbers in this assay, from the lowest: compounds 1, 2 and 3 (each within the scatter of the next).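

Compound 1 and compound 2 both carried chlorine on the ring, whereas compound 3 carries only fluorine. In this assay this replacement gives no change at the digits printed from compound 2 to compound 3 (within the scatter) and also no change at the digits printed from compound 1 to compound 3 (within the scatter). Among these three compounds, neither the kind of halogen nor the number of halogens on this phenyl ring separates the doses. No evidence bears on the reason for this flat result. On these data alone, all three groups are halogen-bearing phenyl rings, so it remains open whether an amine or a carboxylic acid on the ring, or a longer chain in place of the ring, would shift the dose.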